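This account rests on a few compounds, and the source may have more. Where it says the series, first, only, none or still open, it means among the compounds named here.

Compound 1 `FC(F)(F)c1cccc(/N=N/N2CCCC2)c1` gives > 100000 nM in an ADME assay on MT4 cells (Homo sapiens) for cytotoxicity, read by MTT assay, with a stated time of 96 h (a lower number here means that less compound is tolerated, a higher number that more compound is tolerated), a limit of the assay rather than a number.
Compound 2 `CN(C)CCCN(/N=N/c1c(F)cccc1F)c1ccccc1` gives 23000 nM in this assay.
Compound 3 `c1ccc(/N=N/N2CCN(c3ccccc3)CC2)cc1` gives 33000 nM in this assay.

Of the two numbers recorded, compound 3 carries the higher, but compound 2 sits within the scatter of it, so no order between them can be read; the remaining value is a limit (the limit of > 100000 nM in this assay, at which 1 of the 3 values shown sits). Compound 4 `CCOC(=O)N1CCN(/N=N/c2ccccc2)CC1` differs from compound 3 in one place: ethoxycarbonyl in place of phenyl on an amine nitrogen in a ring. Among the compounds with values here, no measured pair shows this change, so there is nothing to calibrate it against. In this assay the step is expected to be small, towards a higher number or none beyond the scatter. Compound 4 is therefore estimated at 50000 nM, with a range from 20000 nM to 150000 nM. The expected step is a 1.5-fold higher number from compound 3 to compound 4 (0.18 log units; within the scatter).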

Compound 4, half-maximal cytotoxic concentration: 100000 nM
Compound 4: the middle estimate sits 2.0-fold (0.30 log units) below what was measured; the measured number falls inside the stated range.
By their numbers in this assay, from the lowest: compounds 2 and 3 (each within the scatter of the next); then compound 4.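

In this assay, within the data shown here, ethoxycarbonyl in place of phenyl on an amine nitrogen in a ring gives a 3.0-fold higher number from compound 3 to compound 4 (0.48 log units; beyond the scatter) and so provides the first readable step at this position. This shows that the position is not silent to a change of group: more compound is tolerated with ethoxycarbonyl there than with phenyl. Compound 1 carries a limit, and any further rise at this position may meet it: the limit of > 100000 nM in this assay, at which 1 of the 4 values shown sits.

The compounds shown leave open whether the carbonyl, the ethyl part or the loss of phenyl accounts for the step. They also leave open how a simple alkyl chain, an amine or a carboxylic acid would behave on that nitrogen.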